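A few compounds are considered here, and "the series" means these few. Any claim that something is new, unique, unknown or untested is made for them only; others in the source may bear on it.

Measured so far in a functional assay on the whole organism (stomach) for inhibition, with Canis familiaris (Canis lupus familiaris) as the target, at a dose of 2 mg/kg by the intravenous route; a lower number here means a weaker effect, a higher number a stronger effect of the compound at the dose given:

- compound 1, `Cc1cn2cccc(OCc3ccccc3)c2n1`: 61%
- compound 2, `Cc1nc2c(OCc3ccccc3)cccn2c1CO`: 80%

Among the measured compounds shown here, compound 2 stands at the top of these two numbers; the nearest is compound 1, and the one step recorded, a number 19 percentage points higher from compound 1 to compound 2 (beyond the scatter), is the only change so far and lies beyond the scatter. Compound 3, `CC(=O)OCc1c(C)nc2c(OCc3ccccc3)cccn12`, is not yet measured. It differs from compound 2 by acetyl in place of hydrogen on an oxygen on a saturated carbon. For the measured compounds named here, no measured step bears directly on this change: the only step known describes the arrival of the hydroxymethyl group itself, not the capping of its oxygen by acetyl, and it was modest in size. With nothing comparable to draw on, compound 3 is expected to stay close to compound 2, giving an estimated step of a number 5 percentage points lower from compound 2 to compound 3 (within the scatter) that need not exceed the scatter. Compound 3 is therefore expected to read about 75%, within a range from 55% to 92%.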

Compound 3, a percentage reported as inhibition, in the whole organism at one dose (the size of the read-out at that dose, not a potency): 54%
Estimate against measurement, compound 3: 21 percentage points above; the whole stated range lies above it.
By their numbers in this assay, from the lowest: compounds 3 and 1 (each within the scatter of the next); then compound 2.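

In this assay, the gain that came with hydroxymethyl proves sensitive to what sits on its oxygen: acetyl in place of the hydrogen gives (a number 26 percentage points lower from compound 2 to compound 3 (beyond the scatter)), so this oxygen is not a site where a change passes unnoticed. Set against the core of compound 1, acetoxymethyl in place of hydrogen on the aromatic carbon gives (a number 7 percentage points lower from compound 1 to compound 3 (within the scatter)), so at this dose the acetoxymethyl group keeps none of the gain that hydroxymethyl showed. What lies behind the drop at this oxygen cannot be said from the information available here.

As far as these compounds go, whether the loss belongs to acetyl in particular or to any cap on this oxygen remains open, and a methyl ether or a carbamate there would separate the two. From the compounds shown here alone, it is equally open whether another group on the same aromatic carbon, such as an aminomethyl group or a longer hydroxyethyl chain, would match the reading of compound 2 (80%).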